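Swapping an Amine on Two Related Cores

A few compounds are considered here, and "the series" means these few. Any claim that something is new, unique, unknown or untested is made for them only; others in the source may bear on it.

Three compounds have been measured:
compound 1, `CCN(CC)c1ccc(/C=C2\C(=O)N(c3ccccc3)C(=S)N2C)cc1`, 1960 nM;
compound 2, `CN1C(=S)N(c2ccccc2)C(=O)/C1=C\c1ccc(N(C)CCCO)cc1`, 2720 nM;
compound 3, `CCN(CC)c1ccc(/C=C2\C(=O)N(C3CCCCC3)C(=S)N2C)c(OC)c1`, 1950 nM.

All three numbers come from an assay on isolated protein for inhibition of NADPH oxidase 2 (Homo sapiens), read by chemiluminescence, in the presence of a further agent that is not named here; a higher number here means a weaker inhibitor, a lower number a stronger inhibitor. Compound 1 and compound 2 share one core and differ in a single place: (3-hydroxypropyl)(methyl)amino in place of diethylamino on an aromatic carbon. The step, a 1.4-fold higher number from compound 1 to compound 2 (0.14 log units; within the scatter), lies within the scatter, so the two cannot be told apart. Compound 3 carries the same diethylamino group on another core; how the two cores differ is not broken down here. Compound 3 and compound 1 give numbers within the scatter of each other, and so do compound 3 and compound 2.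

Compound 4, `COc1cc(N(C)CCCO)ccc1/C=C1\C(=O)N(C2CCCCC2)C(=S)N1C`, has not yet been measured. It stands to compound 3 as compound 2 stands to compound 1: (3-hydroxypropyl)(methyl)amino in place of diethylamino on an aromatic carbon. The surroundings are not identical, since in compound 4 the new group sits meta to a methoxy group and para to a large group, whereas in compound 2 it is only para to a large group, so this is the same kind of change rather than the same change. For compound 4 in this assay a step of a 1.4-fold higher number from compound 3 to compound 4 (0.14 log units; within the scatter) is expected, because the earlier step of a 1.4-fold higher number from compound 1 to compound 2 (0.14 log units; within the scatter) stayed within the scatter. Compound 4 is estimated at 2700 nM, between 1300 nM and 5600 nM.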

Compound 4, half-maximal inhibitory concentration: 990 nM
Compound 4: the middle estimate sits 2.7-fold (0.44 log units) above what was measured, and the stated range ends above it.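

In this assay, putting (3-hydroxypropyl)(methyl)amino in place of diethylamino gives a 2.0-fold lower number from compound 3 to compound 4 (0.29 log units; within the scatter), so this step alone does not tell the two compounds apart. Set beside the earlier step, though, the same change does not give the same result on the two cores: the same change on two cores in this assay, a 1.4-fold higher number (0.14 log units; within the scatter) from compound 1 to compound 2 and a 2.0-fold lower number (0.29 log units; within the scatter) from compound 3 to compound 4, 2.7-fold (0.44 log units) apart, beyond the scatter of two such steps This shows that a step read on one core in this series is not a safe forecast of the step on the other, yet it rests on only two pairs and does not show what in the cores lies behind the gap, nor whether the gap would hold for any other change.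

The compounds shown do not separate the methoxy group from the other differences between the two cores, so which of them matters stays open. Also open, on these data alone, is how the step would run with a cyclic amine such as morpholine, or with a longer chain ending in a hydroxyl group, on either core.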